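Pentyl on Selenium: Two Cores, One Change

A few compounds are considered here, and "the series" means these few. Any claim that something is new, unique, unknown or untested is made for them only; others in the source may bear on it.

Compound 1 `Nc1nc([SeH])nc2ncccc12` and compound 3 `Nc1nc([SeH])nc2ccccc12` rest on two different cores, and the difference between the two cores is not broken down here. Each carries a hydrogen on a selenium. In a functional assay on MCF7 cells (Homo sapiens) for cytotoxicity, read by MTT assay, with a stated time of 72 h (on this read-out higher numbers stand for lower toxicity in this test and lower numbers for higher toxicity in this test), compound 1 gives > 100000 nM, which is a limit of the assay rather than a number. In this assay compound 3 gives > 100000 nM, again a limit. Compound 2 `CCCCC[Se]c1nc(N)c2cccnc2n1` differs from compound 1 in one place: pentyl in place of hydrogen on a selenium. In this assay compound 2 gives 85000 nM, and the step of an at least 1.1-fold lower number from compound 1 to compound 2 (0.07 log units; that floor lies within the scatter) has only a floor, since it rests on (the limit of > 100000 nM in this assay, at which 2 of the 3 values shown sit).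

Compound 4 `CCCCC[Se]c1nc(N)c2ccccc2n1` stands to compound 3 as compound 2 stands to compound 1: pentyl in place of hydrogen on a selenium. The same change is thus made on the second core. The step from compound 3 to compound 4 in this assay is expected to be modest, about as large as the earlier one, resting on an at least 1.1-fold lower number from compound 1 to compound 2 (0.07 log units; that floor lies within the scatter). For compound 4 in this assay a value near 80000 nM is expected, within 40000 nM to 150000 nM. The expected step that this means is an at least 1.2-fold lower number from compound 3 to compound 4 (0.09 log units; that floor lies within the scatter).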

Compound 4, concentration lethal to 50% of the cells: 90400 nM
The estimate for compound 4 lay 1.1-fold (0.05 log units) below the measured number; low and high end bracket the measured number.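

In this assay, pentyl in place of hydrogen on a selenium on the second core gives an at least 1.1-fold lower number from compound 3 to compound 4 (0.04 log units; that floor lies within the scatter), which is only a floor and does not establish a real change. Set beside the same change on the first core, this step cannot be said to match or to differ from the earlier one: the same change on two cores in this assay, an at least 1.1-fold lower number (0.07 log units; that floor lies within the scatter) from compound 1 to compound 2 and an at least 1.1-fold lower number (0.04 log units; that floor lies within the scatter) from compound 3 to compound 4; the limit leaves it open whether they differ The result therefore does not show that the change carries over from one core to the other by a similar amount, only that both pentyl compounds give a measured number, since both hydrogen compounds sit at a limit: the limit of > 100000 nM in this assay, at which 2 of the 4 values shown sit.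

The compounds shown leave open what a methyl, a longer chain or a benzyl on the selenium would give in this assay. With hydrogen and pentyl as the only two groups shown there, and with two cores, no trend with chain length can be read.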